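Fluoro for nitro: expected effect on compound 4

The source may report more compounds than this note shows. Statements on the series, on what has been measured and on what is new or still open speak of the compounds shown alone.

Three compounds on a shared core have numbers in an assay on isolated protein for inhibition of Amine oxidase [flavin-containing] B (Homo sapiens), read by Amplex Red, with a stated time of 15 min; a higher number here means a weaker inhibitor, a lower number a stronger inhibitor. Compound 1 `CC(=O)c1ccc(OCc2ccccc2[N+](=O)[O-])cc1` gives 284 nM. Compound 2 `CC(=O)c1ccc(OCc2cccc([N+](=O)[O-])c2)cc1` gives 104 nM; compound 1 and compound 2 have the same atoms joined differently, and the difference between the two cores is not broken down here. Compound 3 `CC(=O)c1ccc(OCc2ccccc2F)cc1` gives 56.9 nM. The change from compound 1 to compound 3 is fluoro in place of nitro on an aromatic carbon, and it made a 5.0-fold lower number from compound 1 to compound 3 (0.70 log units; beyond the scatter). Compound 2 and compound 3 sit within the scatter of each other, while compound 1 lies beyond the scatter from both.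

Compound 4 `CC(=O)c1ccc(OCc2cccc(F)c2)cc1` is not yet measured. It stands to compound 2 as compound 3 stands to compound 1: fluoro in place of nitro on an aromatic carbon. This is the same kind of change, not the same one: in compound 1 the leaving nitro is ortho to a large group, in compound 2 it is meta to a large group. For compound 4 in this assay a step of a 3.0-fold lower number from compound 2 to compound 4 (0.47 log units; beyond the scatter) is expected, resting on the measured step of a 5.0-fold lower number from compound 1 to compound 3 (0.70 log units; beyond the scatter) and taken somewhat smaller; the place is not the same. Compound 4 is estimated at 35 nM, expected within 12 nM to 90 nM.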

Compound 4, half-maximal inhibitory concentration: 83.1 nM
Compound 4: middle estimate off by 2.4-fold (0.38 log units), on the low side; the measured number falls inside the stated range.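

In this assay, fluoro in place of nitro on an aromatic carbon does not carry over from one core to the other at a fixed size: the same change on two cores in this assay, a 5.0-fold lower number (0.70 log units; beyond the scatter) from compound 1 to compound 3 and a 1.3-fold lower number (0.10 log units; within the scatter) from compound 2 to compound 4, 4.0-fold (0.60 log units) apart, beyond the scatter of two such steps

With the group meta to a large group, the change gives a 1.3-fold lower number from compound 2 to compound 4 (0.10 log units; within the scatter), so no gain from the swap can be claimed on that core, and the larger step on the core of compound 1 should not be used as a general value for this change. The two steps show that the size of the step depends on the core, but one pair per core cannot show what sets that size, nor how the change would behave on any further core.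

The compounds shown leave open how an amine, a nitrile or a carboxylic acid would compare with nitro and fluoro at the same places. They also leave open whether either step would hold if the acetyl group of the shared core were replaced by a longer chain.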